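The source may report more compounds than this note shows. Statements on the series, on what has been measured and on what is new or still open speak of the compounds shown alone.

Compound 1 `O=S(=O)(Nc1cccc(CO)c1)c1ccc(-c2ccc(Br)cc2)cc1` is the starting point of this account. In an ADME assay on microsomes from liver (Homo sapiens) for metabolic stability, read by LC-MS, tested at 3 uM (a lower number here means that the compound disappears faster, a higher number that the compound lasts longer), compound 1 gives 0.7 h. Compound 2 `O=S(=O)(Nc1cccc(CO)c1)c1ccc(-c2ccc(F)cc2F)cc1` differs from it in one place; how the two cores differ is 4-bromophenyl in place of 2,4-difluorophenyl on an aromatic carbon. In this assay compound 2 gives 0.5 h, so that there is a 1.4-fold lower number from compound 1 to compound 2 (0.15 log units; within the scatter). Compound 3 `Cc1c(CO)cccc1NS(=O)(=O)c1ccc(-c2ccc(F)cc2F)cc1` differs from compound 2 by methyl in place of hydrogen on an aromatic carbon. In this assay compound 3 gives 0.333 h, which amounts to a 1.5-fold lower number from compound 2 to compound 3 (0.18 log units; within the scatter). Compound 4 `Cc1ccc(CO)cc1NS(=O)(=O)c1ccc(-c2ccc(Br)cc2)cc1` has not yet been measured; it differs from compound 1 by methyl in place of hydrogen on an aromatic carbon. Among the measured compounds shown here, this is the same kind of change as the one from compound 2 to compound 3, though not the same: in compound 3 the methyl sits ortho to a hydroxymethyl group, whereas in compound 4 it sits para to a hydroxymethyl group, and in both it sits ortho to a large group. Because the earlier step was a 1.5-fold lower number from compound 2 to compound 3 (0.18 log units; within the scatter), the expected step is a 1.4-fold lower number from compound 1 to compound 4 (0.15 log units; within the scatter), a size that rests on that single precedent alone. The estimate for compound 4 in this assay is 0.5 h, expected to fall between 0.25 h and 1 h.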

Compound 4, half-life: 0.15 h
The estimate for compound 4 lay 3.3-fold (0.52 log units) above the measured number; the whole stated range lies above it.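

In this assay, methyl in place of hydrogen gives a 4.7-fold lower number from compound 1 to compound 4 (0.67 log units; beyond the scatter), so the size of this change did not carry from one core to the other, and the earlier step was no safe guide to this one: the same change on two cores in this assay, a 1.5-fold lower number (0.18 log units; within the scatter) from compound 2 to compound 3 and a 4.7-fold lower number (0.67 log units; beyond the scatter) from compound 1 to compound 4, 3.1-fold (0.49 log units) apart, beyond the scatter of two such steps. Among the compounds shown here, only two pairs bear on this, and the two cores differ in their 4-bromophenyl and 2,4-difluorophenyl groups while the methyl also stands in a different place relative to the hydroxymethyl group. The result therefore does not show whether the core, the place of the methyl or both set the size of the step, and it gives no rule for any further core.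

The compounds shown leave open what a methyl does at one and the same place on both cores. They also leave open how this assay would respond to a methoxy group or a chlorine atom on that carbon, or to an amine or a carboxylic acid in place of the hydroxymethyl group.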